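The source may report more compounds than this note shows. Statements on the series, on what has been measured and on what is new or still open speak of the compounds shown alone.

Measured in an ADME assay on KB cells (Homo sapiens) for cytotoxicity; on this read-out higher numbers stand for an effect only at larger amounts of compound and lower numbers for an effect already at smaller amounts:
compound 1 `CCOC(=O)N1[C@@H]2C=C[C@@](OC)(C(=O)c3c2cc(OC)c(OC)c3OCc2ccc(F)cc2)N1C(=O)OCC`: 51.8 ug/mL
compound 2 `CCOc1c(OC)c(OC)cc2c1C(=O)[C@]1(OC)C=C[C@H]2N(C(=O)OCC(C)C)N1C(=O)OCC(C)C`: > 300 ug/mL
compound 3 `CCOC(=O)N1[C@@H]2C=C[C@@](OC)(C(=O)c3c2cc(OC)c(OC)c3OCc2ccc(OC)cc2)N1C(=O)OCC`: 63.1 ug/mL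

Compound 2 stands at the limit of > 300 ug/mL in this assay, at which 1 of the 3 values shown sits, a limit and not a number. Compound 4 `COc1cc2c(c(OCc3ccc(F)cc3)c1OC)C(=O)[C@]1(OC)C=C[C@H]2N(C(=O)OCC(C)C)N1C(=O)OCC(C)C` differs from it by 4-fluorophenyl in place of methyl on a saturated chain carbon bound to an oxygen on an aromatic ring, which reads as ethoxy to (4-fluorobenzyl)oxy. For the measured compounds named here, the one measured step, a 1.2-fold higher number from compound 1 to compound 3 (0.09 log units; within the scatter), is methoxy in place of fluoro on an aromatic carbon and does not touch this place. Compound 4 shares (4-fluorobenzyl)oxy with compound 1, which gives 51.8 ug/mL, but the two differ elsewhere too. A move to a lower number is therefore expected, of poorly defined size. The expected step is an at least 2.7-fold lower number from compound 2 to compound 4 (0.43 log units; beyond the scatter). For compound 4 the estimate is 110 ug/mL, with an expected range of 35 ug/mL to 300 ug/mL.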

Compound 4, concentration for half-maximal effect: > 300 ug/mL
Compound 4 gave a limit, no number; the forecaster's own chance of this, stated with the estimate: 25%; at least 2.7-fold (0.43 log units) between middle value and limit.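

In this assay, compound 2 and compound 4 both sit at a limit and not at a number, so no step can be read between them: the limit of > 300 ug/mL in this assay, at which 2 of the 4 values shown sit.

The compounds shown leave open whether ethoxy to (4-fluorobenzyl)oxy changes the read-out in this pair at all.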